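A few compounds are considered here, and "the series" means these few. Any claim that something is new, unique, unknown or untested is made for them only; others in the source may bear on it.

Of the compounds shown here, two of this study have been tested so far. Compound 1, with the structure `Cc1ccc(C)c(N2CCN(C(=O)c3oc(C)nc3-c3ccc(F)cc3)CC2)c1`, gives 358 nM in a functional assay on HL-60 cells (Homo sapiens) for inhibition, read by MTT assay, with a stated time of 72 h; on this read-out higher numbers stand for weaker inhibition and lower numbers for stronger inhibition. Compound 2, with the structure `Cc1nc(-c2ccccc2)c(C(=O)N2CCN(c3ccc(C(F)(F)F)cc3)CC2)o1`, shares an oxazole carbonyl piperazine core with compound 1 but carries its aryl groups in the reverse arrangement. In this assay compound 2 reaches only a limit of the assay, > 1000 nM, which is one of the two results and, as the evidence notes, (the limit of > 1000 nM in this assay, at which 1 of the 2 values shown sits). The two compounds differ in several places at once. Among the compounds with values here, no single step between them can be followed, and their values are left to speak for themselves.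

The next compound, compound 3, has the structure `Cc1nc(-c2ccccc2)c(C(=O)N2CCN(c3ccc(F)cc3)CC2)o1`. It differs from compound 2 in one place only: fluoro in place of trifluoromethyl on an aromatic carbon. Since compound 2 sits at the limit, the step to compound 3 is expected to be small, with no direction beyond the usual scatter, so that a step that the limit leaves unreadable from compound 2 to compound 3 is estimated to leave the potency in the same region. Compound 3 is therefore expected to give about 1500 nM in this assay, within a range from 500 nM to 5000 nM.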

Compound 3, half-maximal inhibitory concentration: > 1000 nM
Compound 3: a limit, no number; the forecaster's own chance of this, stated with the estimate: 55%; the middle value lies beyond the limit too.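

Compound 2 and compound 3 both sit at a limit of this assay, so no step can be read between them: the limit of > 1000 nM in this assay, at which 2 of the 3 values shown sit. The compounds shown leave open how far each lies from that limit, and whether going from 4-(trifluoromethyl)phenyl to 4-fluorophenyl changes the result in this assay at all.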